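The compounds below may be only part of what the source reports. "The series", "measured", "known", "first", "only" and "open" are said of these compounds alone.

In an ADME assay on HEK293 cells (Homo sapiens) for cytotoxicity, read by CellTiter-Glo and resazurin assay, with a stated time of 72 h (on this read-out higher numbers stand for an effect only at larger amounts of compound and lower numbers for an effect already at smaller amounts), compound 2, with the structure `CCOC(=O)CCCCCOc1cccc(CN(C(=O)c2ccc(-c3cc(OC)ccc3F)cc2)C(C)C)c1`, gives > 26000 nM; that figure is a limit of the assay and not a measured number. Compound 1, with the structure `CCOC(=O)CCCCCOc1cccc(CN(C(=O)c2ccc(-c3ccc4cc[nH]c4c3)cc2)C(C)C)c1`, gives > 26000 nM in this assay, again a limit rather than a number. Among the compounds with values here, both values sit at the limit of > 26000 nM in this assay, at which 2 of the 2 values shown sit, so the one measured step, a step that the two limits leave unreadable from compound 1 to compound 2, cannot be sized, and it bears on the present question only by showing that exchanging one group at that aromatic carbon for another left the read-out at the limit.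

Compound 3 has the structure `CCOC(=O)CCCCCOc1cccc(CN(C(=O)c2ccc(-c3cccc(C(F)(F)F)c3)cc2)C(C)C)c1` and differs from compound 2 by 3-(trifluoromethyl)phenyl in place of 2-fluoro-5-methoxyphenyl on an aromatic carbon. With no readable step in hand, no change beyond the scatter in this assay is expected in either direction. Compound 3 is therefore expected to give about 40000 nM, somewhere between 15000 nM and 120000 nM, and most likely to be reported once more as a limit. The expected step that this estimate implies is a step that the limit leaves unreadable from compound 2 to compound 3, which is the outcome to be compared with the actual measurement.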

Compound 3, half-maximal effective concentration: > 26000 nM
Compound 3 gave a limit, no number; the forecaster's own chance of this, stated with the estimate: 75%; the middle value lies beyond the limit too.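

Compound 3 gives > 26000 nM in this assay and that figure is a limit, not a number. Within the data shown here, no step among compound 1, compound 2 and compound 3 can be read: the limit of > 26000 nM in this assay, at which 3 of the 3 values shown sit. The compounds shown leave open at what concentration any of the three would reach its half-maximal effect, and whether their aromatic groups differ at all on this read-out.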